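A Trifluoromethyl Added to the Weakly Active Compound 2

The source may hold more compounds than are shown below. What is called first, only, known or untested is meant among the compounds shown, and "the series" means these compounds.

compound 1, `Cc1cccc(NC(=O)COc2ccc3cc(/C=C4/SC(=O)NC4=O)ccc3c2)n1` — in an assay on isolated protein for inhibition of histone deacetylase 8 (Homo sapiens), with a stated time of 1 h (on this read-out lower numbers stand for stronger inhibition and higher numbers for weaker inhibition), compound 1 gives 7500 nM
compound 2, `O=C(COc1ccc2cc(/C=C3/SC(=O)NC3=O)ccc2c1)Nc1cccc(Cl)c1` — in this assay compound 2 gives only a limit, > 50000 nM

Compound 2 therefore stands at the limit of > 50000 nM in this assay, at which 1 of the 2 values shown sits, and no number is known for it. For the measured compounds named here, the single measured step between the two, an at least 6.6-fold higher number from compound 1 to compound 2 (0.82 log units; beyond the scatter), concerns a different exchange on the nitrogen-bound ring, so it says little about the change now at hand. Compound 3, `O=C(COc1ccc2cc(/C=C3/SC(=O)NC3=O)ccc2c1)Nc1cc(Cl)cc(C(F)(F)F)c1`, differs from compound 2 by trifluoromethyl in place of hydrogen on an aromatic carbon. Going by the values given here, there is no measured step in which a group is added to that ring, so the expectation rests on compound 2 alone. Compound 3 is expected to stay at or near the limit, a step that the limit leaves unreadable from compound 2 to compound 3, with no step beyond the scatter. The estimate for compound 3 is 60000 nM, ranging from 20000 nM to 200000 nM, and most likely only a limit will again be reported.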

Compound 3, half-maximal inhibitory concentration: > 50000 nM
Compound 3: a limit, no number; the forecaster's own chance of this, stated with the estimate: 70%; the middle value is on the limit's open side.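

In this assay, trifluoromethyl in place of hydrogen on the 3-chlorophenyl ring, meta to the chloro group, does not bring the compound back to a readable number, so this position has still yielded no value. The step between compound 2 and compound 3 cannot be read, and the series now clusters at one ceiling: the limit of > 50000 nM in this assay, at which 2 of the 3 values shown sit. The exchange of the 6-methylpyridin-2-yl group for 3-chloro-5-(trifluoromethyl)phenyl gives an at least 6.6-fold higher number from compound 1 to compound 3 (0.82 log units; beyond the scatter), which leaves compound 1 as the only one of the three with a number.

Going by these compounds, whether compound 2 and compound 3 truly differ remains unknown, as does the direction of any effect of trifluoromethyl on this ring. Also open, on these data alone, is whether an amine or a carboxylic acid at this position, or the same trifluoromethyl on the 6-methylpyridin-2-yl ring of compound 1, would give a measurable value.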